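From isopropyl to 4-methylphenyl on an aromatic nitrogen

The compounds below may be only part of what the source reports. "The series", "measured", "known", "first", "only" and "open" are said of these compounds alone.

Compound 1 `COc1cc(-c2nccn2C(C)C)cc(OC)c1OC`: > 100000 nM (a limit of the assay)
Compound 2 `COc1cc(-c2nccn2-c2ccc3[nH]ccc3c2)cc(OC)c1OC`: 2300 nM

Both compounds were tested in a functional assay on MDA-MB-468 cells (Homo sapiens) for antiproliferative activity, read by MTT assay, with a stated time of 72 h; on this read-out higher numbers stand for weaker inhibition and lower numbers for stronger inhibition. Compound 1 gives no number in this assay, only a limit, > 100000 nM. Its place on the scale is thus (the limit of > 100000 nM in this assay, at which 1 of the 2 values shown sits). Compound 2, by contrast, gives a true reading of 2300 nM.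

The next compound, compound 3 `COc1cc(-c2nccn2-c2ccc(C)cc2)cc(OC)c1OC`, keeps the core of compound 1 and alters a single group: 4-methylphenyl in place of isopropyl on an aromatic nitrogen. In plain terms, 4-methylphenyl stands in place of isopropyl on an aromatic nitrogen. Going by the values given here, no measured pair isolates this change, so any forecast rests on thin ground. Compound 2 also carries an aromatic group on that nitrogen and reads 2300 nM, which suggests that compound 3 should give a true reading as well. The expected change is an at least 12-fold lower number from compound 1 to compound 3 (1.09 log units; beyond the scatter), towards stronger inhibition and well beyond the scatter, although its true size cannot be fixed while compound 1 has only a limit. For compound 3 the estimated value is 8000 nM, with an expected range from 1000 nM to 60000 nM.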

Compound 3, half-maximal inhibitory concentration: 400 nM
The estimate for compound 3 lay 20-fold (1.30 log units) above the measured number; the measured number lies below the stated range.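

The change from isopropyl to 4-methylphenyl on an aromatic nitrogen brings an at least 250-fold lower number from compound 1 to compound 3 (2.39 log units; beyond the scatter), so this one position, with the core of compound 1 otherwise unchanged, decides between no numerical reading and a true one. Compound 1 has only a limit, so the full size of this step stays unfixed: the limit of > 100000 nM in this assay, at which 1 of the 3 values shown sits.

Compound 2 had already given a true reading with another aromatic group on that nitrogen, but it did not show what the single six-membered aromatic ring of carbon could do on its own; in this assay compound 3 gives 400 nM and compound 2 gives 2300 nM, so the group of compound 2 is not required for a true reading.

From the compounds shown here alone, it remains open what the methyl group of 4-methylphenyl contributes, since a plain phenyl or a 4-methoxyphenyl would be needed to tell that. Going by these compounds, it also remains open whether the aromatic ring itself matters or only the number of atoms entering, a question that a cyclohexyl group on the same nitrogen could begin to settle.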